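The source may hold more compounds than are shown below. What is called first, only, known or untested is meant among the compounds shown, and "the series" means these compounds.

Measured in an ADME assay on WI-38 cells (Homo sapiens) for cytotoxicity, read by sulforhodamine B assay, with a stated time of 24 h; a lower number here means a stronger inhibitor, a higher number a weaker inhibitor:
Compound 1 `CC(=O)N/N=C1\C(=O)Nc2ccc(S(=O)(=O)N3CCOCC3)cc21`: 325000 nM
Compound 2 `CC(=O)c1cccc(/N=C2\C(=O)Nc3ccc(S(=O)(=O)N4CCOCC4)cc32)c1`: 177000 nM

For the measured compounds named here, the values of compound 1 and compound 2 lie within the scatter of each other, so compound 2 stands level with the only other compound measured. The next structure is compound 3 `O=C1Nc2ccc(S(=O)(=O)N3CCOCC3)cc2/C1=N/NS(=O)(=O)c1ccccc1`, and the change is (phenylsulfonyl)amino in place of 3-acetylphenyl on a double-bonded nitrogen. Going by the values given here, one measured step bears on this, a change at the same place: a 1.8-fold lower number from compound 1 to compound 2 (0.26 log units; within the scatter). Among the compounds with values here, that step involves a different pair of groups, so it is only a loose guide, and no measured compound carries (phenylsulfonyl)amino. No step beyond the scatter is therefore expected in this assay, and no direction can be given. Compound 3 is estimated at 220000 nM, with an expected range from 90000 nM to 500000 nM. This estimate means an expected 1.2-fold higher number from compound 2 to compound 3 (0.09 log units; within the scatter).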

Compound 3, half-maximal inhibitory concentration: 302000 nM
For compound 3 the middle estimate is 1.4-fold (0.14 log units) below the measured one; measured number inside the range.
By their numbers in this assay, from the lowest: compounds 2, 3 and 1 (each within the scatter of the next).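

In this assay the change to (phenylsulfonyl)amino on the double-bonded nitrogen gives a 1.7-fold higher number from compound 2 to compound 3 (0.23 log units; within the scatter) and the swap of acetyl for phenylsulfonyl on the amine nitrogen gives a 1.1-fold lower number from compound 1 to compound 3 (0.03 log units; within the scatter) so both new steps stay within the scatter. With a third group at this place, compounds 1, 2 and 3 all stand level, and neither the sulfonyl link nor the phenyl ring it carries separates compound 3 from the other two in this assay. Nothing available accounts for this flat picture.

From the compounds shown here alone, what stays open is whether any group at this place can produce a step beyond the scatter. A free amine, a carboxylic acid or a longer chain on the double-bonded nitrogen would test this, as would changes to the substituents on the phenyl ring of compound 3.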